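A few compounds are considered here, and "the series" means these few. Any claim that something is new, unique, unknown or untested is made for them only; others in the source may bear on it.

Measured so far in a functional assay on U-87MG ATCC cells for inhibition, with U-87 MG (Homo sapiens) as the target, read by MTT assay, with a stated time of 72 h; on this read-out higher numbers stand for weaker inhibition and lower numbers for stronger inhibition:
- compound 1 `Cc1ccnc(NC(c2ccc(F)cc2)c2ccc3cccnc3c2O)c1`: > 10000 nM, a limit and not a number
- compound 2 `Cc1ccnc(NC(c2ccc(OCc3ccccc3)cc2)c2ccc3cccnc3c2O)c1`: 9300 nM
- compound 3 `Oc1c(C(c2ccc(F)cc2)N2CCCCC2)ccc2cccnc12`: 37000 nM

Compound 1 has only a limit to its name: the limit of > 10000 nM in this assay, at which 1 of the 3 values shown sits. Compound 4 `Cc1ccnc(NC(c2ccc3cccnc3c2O)c2c(Cl)cccc2Cl)c1` departs from compound 1 on the saturated chain carbon: 2,6-dichlorophenyl in place of 4-fluorophenyl on a saturated chain carbon bound to an aromatic carbon and a nitrogen on an aromatic ring. Two measured steps start from compound 1. The change at the amine side gives a step that the limit leaves unreadable from compound 1 to compound 3, so it offers no size to work with. The change on the aryl group, closer to the one at hand, gives an at least 1.0-fold lower number from compound 1 to compound 2 (0.03 log units; that floor lies within the scatter). On the strength of that step to compound 2, no step beyond the scatter is expected in this assay. The expected step is a step that the limit leaves unreadable from compound 1 to compound 4. Compound 4 is estimated at 12000 nM, with an expected range of 4000 nM to 40000 nM.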

Compound 4, half-maximal inhibitory concentration: 7200 nM
The estimate for compound 4 lay 1.7-fold (0.22 log units) above the measured number, and the stated range covers the measured number.
By their numbers in this assay, from the lowest: compounds 4 and 2 (each within the scatter of the next); then compound 3.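

In this assay, putting 2,6-dichlorophenyl in place of 4-fluorophenyl gives an at least 1.3-fold lower number from compound 1 to compound 4 (0.14 log units; that floor lies within the scatter), so a second aryl change on this saturated chain carbon yields a measured number, yet no step beyond the scatter can be claimed. The true size of the step stays unreadable because compound 1 has only a limit: the limit of > 10000 nM in this assay, at which 1 of the 4 values shown sits.

The compounds shown leave open whether a single chlorine, a carboxylic acid or an amine on this aryl group would move the number beyond the scatter.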